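A Fluoro Step Repeated on a Propargyloxy Core

The source may hold more compounds than are shown below. What is called first, only, known or untested is meant among the compounds shown, and "the series" means these compounds.

Compound 1, `CCCCOC(=O)c1cc(N2C(=O)C3=C(CCCC3)C2=O)ccc1Cl`, gives 7760 nM in a functional assay on the whole organism with Scenedesmus acutus as the target, with a stated time of 20 h; on this read-out higher numbers stand for weaker inhibition and lower numbers for stronger inhibition.
Compound 2, `CCCCOC(=O)c1cc(N2C(=O)C3=C(CCCC3)C2=O)c(F)cc1Cl`, gives 141 nM in this assay.
Compound 3, `C#CCOc1cc(N2C(=O)C3=C(CCCC3)C2=O)ccc1Cl`, gives 537 nM in this assay.

The change from compound 1 to compound 2 is fluoro in place of hydrogen on an aromatic carbon. This single added fluorine made a large step, a 55-fold lower number from compound 1 to compound 2 (1.74 log units; beyond the scatter). Compound 3 differs from compound 1 in its core: propargyloxy in place of butoxycarbonyl on an aromatic carbon, a change that gave a 14-fold lower number from compound 1 to compound 3 (1.16 log units; beyond the scatter).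

Compound 4, `C#CCOc1cc(N2C(=O)C3=C(CCCC3)C2=O)c(F)cc1Cl`, has not yet been measured. It differs from compound 3 by fluoro in place of hydrogen on an aromatic carbon. Compared with the earlier fluorine addition, the place is described as para to a propargyloxy group rather than para to a butoxycarbonyl group, so this is the same kind of change, not the same change, and the cores differ as told above.

For compound 4 in this assay a step of about a 21-fold lower number from compound 3 to compound 4 (1.33 log units; beyond the scatter) is expected, somewhat smaller than the earlier one; this expectation rests on the step of a 55-fold lower number from compound 1 to compound 2 (1.74 log units; beyond the scatter) seen with the other core. Compound 4 is accordingly estimated at 25 nM, with a likely range from 8 nM to 80 nM.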

Compound 4, half-maximal inhibitory concentration: 141 nM
Beside the measured number, compound 4's estimate is 5.6-fold (0.75 log units) below it; measured number above the stated range.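

On the propargyloxy core the added fluorine still lowers the number in this assay, but with a 3.8-fold lower number from compound 3 to compound 4 (0.58 log units; beyond the scatter) the step is much smaller, so its direction carries over and its size does not: the same change on two cores in this assay, a 55-fold lower number (1.74 log units; beyond the scatter) from compound 1 to compound 2 and a 3.8-fold lower number (0.58 log units; beyond the scatter) from compound 3 to compound 4, 14-fold (1.16 log units) apart, beyond the scatter of two such steps

Seen from the other side, replacing butoxycarbonyl with propargyloxy lowers the number when no fluorine is present, yet the fluorine-bearing pair shows no change at the digits printed from compound 2 to compound 4 (within the scatter): the same change on two cores in this assay, a 14-fold lower number (1.16 log units; beyond the scatter) from compound 1 to compound 3 and no change at the digits printed (within the scatter) from compound 2 to compound 4, 14-fold (1.16 log units) apart, beyond the scatter of two such steps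

The two changes therefore do not simply add up here, and a step measured on one core is a poor guide to its size on another, although two cores give no rule for the wider series and these numbers do not show why the steps differ.

The compounds shown leave open how the fluorine step behaves when the propargyloxy or butoxycarbonyl group gives way to something else, such as an amine, a carboxylic acid or a longer ether chain. They also leave open whether chloro in place of the added fluoro would show the same dependence on the core.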